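Piperazin-1-yl in place of (2-hydroxyethyl)amino: working notes

The source may hold more compounds than are shown below. What is called first, only, known or untested is meant among the compounds shown, and "the series" means these compounds.

Measured so far in a functional assay on K562 cells (Homo sapiens) for cytotoxicity, read by fluorescence, with a stated time of 72 h (a higher number here means a weaker inhibitor, a lower number a stronger inhibitor), for this series:
compound 1 (`CC(C)c1n[nH]c2c(NCc3ccc(-c4ccccn4)cc3)nc(S(C)(=O)=O)nc12`) gives 640 nM
compound 2 (`CC(C)c1n[nH]c2c(NCc3ccc(-c4ccccn4)cc3)nc(NCCO)nc12`) gives 38 nM
compound 3 (`CC(C)c1n[nH]c2c(NCc3ccc(-c4ccccn4)cc3)nc(NCC(N)CO)nc12`) gives 700 nM

Compound 2 stands lowest of the three, and its steps to compound 1 and compound 3 both lie beyond the scatter. The next compound to be read is compound 4 (`CC(C)c1n[nH]c2c(NCc3ccc(-c4ccccn4)cc3)nc(N3CCNCC3)nc12`), which keeps the rest of compound 2 and changes one group: piperazin-1-yl in place of (2-hydroxyethyl)amino on an aromatic carbon. The piperazin-1-yl sits on an aromatic carbon between two ring nitrogen atoms, the place where compound 1, compound 2 and compound 3 also differ.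

Within the data shown here, three measured steps bear on this change. The step of a 17-fold lower number from compound 1 to compound 2 (1.23 log units; beyond the scatter) is large, and so is the step of an 18-fold higher number from compound 2 to compound 3 (1.27 log units; beyond the scatter), while the step of a 1.1-fold higher number from compound 1 to compound 3 (0.04 log units; within the scatter) stays within the scatter. Among the measured compounds shown here, both other groups at this place therefore give clearly higher numbers than compound 2, though that rests on only two compounds. No ring at this place has been measured yet.

A step toward a higher number is expected in this assay, probably smaller than the large steps above. The estimated step is a 3.4-fold higher number from compound 2 to compound 4 (0.53 log units; beyond the scatter) on these grounds. Compound 4 is expected at 130 nM with an estimated range of 30 nM to 550 nM for now.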

Compound 4, half-maximal inhibitory concentration: 17 nM
For compound 4 the middle estimate is 7.6-fold (0.88 log units) above the measured one, outside the stated range (below it).
By their numbers in this assay, from the lowest: compound 4; then compound 2; then compounds 1 and 3 (each within the scatter of the next).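

In this assay, a ring is accepted on this aromatic carbon between two ring nitrogen atoms: the step is a 2.2-fold lower number from compound 2 to compound 4 (0.35 log units; beyond the scatter), a modest one, and it takes piperazin-1-yl past (2-hydroxyethyl)amino, until now the group with the lowest number here. The large steps of a 41-fold lower number from compound 3 to compound 4 (1.61 log units; beyond the scatter) and a 38-fold lower number from compound 1 to compound 4 (1.58 log units; beyond the scatter) show how widely this place separates its groups, and the first of them shows that heavy-atom count alone does not set the number, since the groups of compound 3 and compound 4 have the same count. Nothing at hand accounts for these differences.

The compounds shown leave open whether the ring itself or its second nitrogen carries the step, a question that morpholin-4-yl or piperidin-1-yl at this place would address. Also open, on these data alone, is how far a methyl or 2-hydroxyethyl group on the free ring nitrogen would move the number, and whether the same order of groups holds when the rest of the shared core is changed.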